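The source may hold more compounds than are shown below. What is called first, only, known or untested is meant among the compounds shown, and "the series" means these compounds.

Working notes on the series. In a functional assay on HEK293 cells (Homo sapiens) for inhibition (a lower number here means a stronger inhibitor, a higher number a weaker inhibitor), compound 1 (`CCCCCCCCCCCCS(=O)(=O)NCCCNCCCNCCCCNCCCNCCCNS(=O)(=O)CCCCCCCCCCCC`) gives 10300 nM as its half-maximal inhibitory concentration. Compound 2 (`CCCCCCCCCCCCS(=O)(=O)NCCCN(CCCNCCCCNCCCN)CCCNS(=O)(=O)CCCCCCCCCCCC`) gives 13200 nM on the same read-out, and these two values lie within the scatter of each other, so neither stands apart.

Compound 3 (`CCCCCCCCCCCCS(=O)(=O)NCCCN(CCCNCCCNCCCCNCCCN)CCCNS(=O)(=O)CCCCCCCCCCCC`) has not yet been measured. Relative to compound 2, its structure changes on a saturated chain carbon, three bonds along the chain from an amine nitrogen ((4-((3-aminopropyl)amino)butyl)amino in place of ((3-aminopropyl)amino)methyl on a saturated chain carbon, three bonds along the chain from an amine nitrogen). Among the measured compounds shown here, the series holds no measured step that shows what such a change does. For the measured compounds named here, the only guide is the narrow spread of the two values already in hand, with compound 1 at 10300 nM and compound 2 at 13200 nM on the same scale.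

In this assay the expected step is small, with no firm direction and probably nothing beyond the scatter (a 1.2-fold lower number from compound 2 to compound 3 (0.08 log units; within the scatter)). For compound 3 the estimated value is 11000 nM with an expected range from 4500 nM to 25000 nM on this read-out.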

Compound 3, half-maximal inhibitory concentration: 16400 nM
The estimate for compound 3 lay 1.5-fold (0.17 log units) below the measured number; the range from low to high includes it.
By their numbers in this assay, from the lowest: compounds 1, 2 and 3 (each within the scatter of the next).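

In this assay, putting (4-((3-aminopropyl)amino)butyl)amino in place of ((3-aminopropyl)amino)methyl on a saturated chain carbon, three bonds along the chain from an amine nitrogen, gives a 1.2-fold higher number from compound 2 to compound 3 (0.09 log units; within the scatter). Among the compounds shown here, this is the first step read at this position, and it shows that the larger entering group, which carries an added amine nitrogen, leaves the value within the scatter of that for the smaller group, so the read-out does not separate these two chain lengths. Nothing in hand bears on why the step is this small.

The compounds shown leave open whether a different end group on this branch, such as a guanidine or a carboxylic acid in place of the terminal amine, would carry the value beyond the scatter. Also open, from the compounds shown here alone, is whether an octyl chain in place of each dodecyl chain would do so, and thus whether the sulfonyl side of the series offers more room for change than the polyamine branch.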